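Butyl in place of bromo on a sulfonamide aryl ring

This account rests on a few compounds, and the source may have more. Where it says the series, first, only, none or still open, it means among the compounds named here.

Within the data shown here, compound 3 `O=C1NCCN1c1ccc(S(=O)(=O)Nc2ccc(Br)cc2)cc1` is one of three compounds measured in a functional assay on HT-29 cells (Homo sapiens) for antiproliferative activity, read by sulforhodamine B assay, with a stated time of 48 h (a lower number here means a stronger inhibitor, a higher number a weaker inhibitor), where compound 3 gives 300 nM. Compound 1 `CCc1ccccc1NS(=O)(=O)c1ccc(N2CCNC2=O)cc1` gives 240 nM, and compound 2 `CCCCOc1ccc(NS(=O)(=O)c2ccc(N3CCNC3=O)cc2)cc1` gives 630 nM. Compound 3 thus stands second highest of the three numbers, within the scatter of compound 1 (a 1.3-fold higher number from compound 1 to compound 3 (0.10 log units; within the scatter)) and apart from compound 2 by a modest step (a 2.1-fold lower number from compound 2 to compound 3 (0.32 log units; beyond the scatter)).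

Compound 4 `CCCCc1ccc(NS(=O)(=O)c2ccc(N3CCNC3=O)cc2)cc1` differs from compound 3 in one place: butyl in place of bromo on an aromatic carbon. Among the measured compounds shown here, the step that bears on this is the one from compound 2 to compound 3, where bromo replaced a four-carbon butoxy chain and the number fell modestly. Compound 4 puts a four-carbon butyl chain back at the same place, so a modest move in the opposite direction, a somewhat higher number, is expected, though the exchange of butoxy for butyl is itself untested here.

Compound 4 is therefore expected to give 450 nM in this assay, with a likely range from 200 nM to 1000 nM, an expected step of a 1.5-fold higher number from compound 3 to compound 4 (0.18 log units; within the scatter).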

Compound 4, half-maximal inhibitory concentration: 610 nM
Estimate against measurement, compound 4: 1.4-fold (0.13 log units) below, and the stated range covers the measured number.
By their numbers in this assay, from the lowest: compounds 1 and 3 (each within the scatter of the next); then compounds 4 and 2 (each within the scatter of the next).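

In this assay, butyl at this place, on an aromatic carbon para to a large group, moves the number away from that of the bromo compound by a modest step, a 2.0-fold higher number from compound 3 to compound 4 (0.31 log units; beyond the scatter). Among these compounds, exchanging butoxy for butyl, which the earlier compounds left untested, gives no readable difference, a 1.0-fold lower number from compound 2 to compound 4 (0.01 log units; within the scatter), so at this place the two chains cannot be told apart and both stand apart from bromo. Nothing measured here explains why the two chains behave alike or why they differ from bromo.

As far as these compounds go, whether a shorter chain such as methyl, or a longer chain such as hexyl, would stay with butyl and butoxy remains open. So does the standing at this place of groups such as an amine or a carboxylic acid.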